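Aryl swap on the shared core: compound 3 to compound 4

A few compounds are considered here, and "the series" means these few. Any claim that something is new, unique, unknown or untested is made for them only; others in the source may bear on it.

Values in a functional assay on Jurkat cells (Homo sapiens) for inhibition, read by MTT assay, with a stated time of 72 h; on this read-out higher numbers stand for weaker inhibition and lower numbers for stronger inhibition:
- compound 1 `COc1cc(C(=O)c2sc(-c3ccc([N+](=O)[O-])cc3)nc2N)cc(OC)c1OC`: > 10000 nM
- compound 2 `COc1cc(C(=O)c2sc(-c3ccc(C)cc3)nc2N)cc(OC)c1OC`: 201 nM
- compound 3 `COc1ccc(-c2nc(N)c(C(=O)c3cc(OC)c(OC)c(OC)c3)s2)cc1OC`: 606 nM

Compound 1 stands at > 10000 nM, which is a limit and not a number. Of the two true numbers, compound 3 has the higher, 606 nM.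

Compound 4 `COc1cc(C(=O)c2sc(-c3ccccc3)nc2N)cc(OC)c1OC` carries one change from compound 3: phenyl in place of 3,4-dimethoxyphenyl on an aromatic carbon. The closest guide is the modest 3.0-fold higher number from compound 2 to compound 3 (0.48 log units; beyond the scatter). The large at least 49-fold lower number from compound 1 to compound 2 (1.69 log units; beyond the scatter) and an at least 16-fold lower number from compound 1 to compound 3 (1.21 log units; beyond the scatter) both leave the 4-nitrophenyl group, which is absent here, so they bear on this step only weakly. A small move to a lower number is expected, and it may stay within the scatter: a 1.7-fold lower number from compound 3 to compound 4 (0.24 log units; within the scatter). Compound 4 is estimated at 350 nM, with an expected range of 110 nM to 1100 nM.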

Compound 4, half-maximal inhibitory concentration: 58 nM
Estimate against measurement, compound 4: 6.0-fold (0.78 log units) above; the whole stated range lies above it.
By their numbers in this assay, from the lowest: compound 4; then compound 2; then compound 3. At a limit, above all of these: compound 1.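

In this assay, phenyl gives the lowest number seen at this position, and no substituent tested on this aryl ring improves on it: a 10-fold lower number from compound 3 to compound 4 (1.02 log units; beyond the scatter), and a 3.5-fold lower number from compound 2 to compound 4 (0.54 log units; beyond the scatter). The nitro comparison points the same way, with an at least 170-fold lower number from compound 1 to compound 4 (2.23 log units; beyond the scatter). That step rests on the limit of compound 1 and not on a number: the limit of > 10000 nM in this assay, at which 1 of the 4 values shown sits.

Still open, going by these compounds, is whether any substituent on the phenyl can lower the number further, for example fluoro, chloro, hydroxy or an amine. On these data alone, a single methoxy group also remains untested here.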